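The source may report more compounds than this note shows. Statements on the series, on what has been measured and on what is new or still open speak of the compounds shown alone.

The measured compounds are: compound 1 `COc1cc(C)cc(-c2nn(CC#N)cc2-c2ccc(-c3cccc(C(C)=O)c3)nc2)c1` with 4360 nM in a functional assay on UACC-62 cells (Homo sapiens) for inhibition, read by sulforhodamine B assay, with a stated time of 48 h; on this read-out higher numbers stand for weaker inhibition of growth and lower numbers for stronger inhibition of growth; compound 2 `Cc1cc(O)cc(-c2nn(CC#N)cc2-c2ccnc(-c3ccc(Oc4ccccc4)cc3)c2)c1` with 4670 nM; compound 3 `COc1cc(C)cc(-c2nn(CC#N)cc2-c2ccnc(-c3ccc(N(C)C)cc3)c2)c1` with 337 nM.

Compound 3 gives the lowest number of the three. The nearest to it is compound 1, whose number is higher by a margin beyond the usual scatter, and compound 2 lies further still. Compound 4 `Cc1cc(O)cc(-c2nn(CC#N)cc2-c2ccnc(-c3ccc(N(C)C)cc3)c2)c1` is not yet measured. It differs from compound 3 in one place: hydrogen in place of methyl on an oxygen on an aromatic ring. Among the measured compounds shown here, no pair among the measured compounds isolates this change, so no measured step guides the expectation; compound 2 carries a hydroxy group, but its other parts differ too. Compound 4 is expected to stay close to compound 3, with a modest weakening, a step of a 1.6-fold higher number from compound 3 to compound 4 (0.21 log units; within the scatter). In this assay the value of compound 4 is estimated at 550 nM, within 150 nM to 2000 nM.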

Compound 4, concentration for 50% growth inhibition: 3050 nM
Compound 4: middle estimate off by 5.5-fold (0.74 log units), on the low side; measured number outside the range, above it.
By their numbers in this assay, from the lowest: compound 3; then compounds 4, 1 and 2 (each within the scatter of the next).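

In this assay, methoxy to hydroxy on the aromatic ring is no small change: with dimethylamino in place, it gives a step beyond the scatter (a 9.1-fold higher number from compound 3 to compound 4 (0.96 log units; beyond the scatter)). With hydroxy held constant, dimethylamino in place of phenoxy stays within the scatter (a 1.5-fold lower number from compound 2 to compound 4 (0.19 log units; within the scatter)), so that exchange shows no clear effect on this background. Nothing at hand accounts for the loss. Open, as far as these compounds go, is whether ethoxy or an amine in place of methoxy would hold the number of compound 3, and whether methoxy to hydroxy costs as much with phenoxy present.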